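Chloro for fluoro on the fused core, repeated

This account rests on a few compounds, and the source may have more. Where it says the series, first, only, none or still open, it means among the compounds named here.

The series holds three measured compounds. Compound 2 `CCCCC#Cc1c(C)[nH]c2ccc(F)cc2c1=O` gives 5.64 in a physicochemical assay for lipophilicity, at pH 7.4; a higher number here means a more lipophilic compound, a lower number a more polar compound. Compound 1 `CCCCC#Cc1c(C)[nH]c2ccc(Cl)cc2c1=O` gives 2.98, and the step of a number 2.66 log units lower from compound 2 to compound 1 (beyond the scatter) follows the change (chloro in place of fluoro on an aromatic carbon). Compound 3 `CCc1c(C)[nH]c2cc(OC)c(F)cc2c1=O` gives 1.2 in this assay, the lowest of the three; how its core differs from that of compound 2 is not broken down here. Compound 4 `CCc1c(C)[nH]c2cc(OC)c(Cl)cc2c1=O` is not yet measured and differs from compound 3 by chloro in place of fluoro on an aromatic carbon. The place lines are not the same word for word: in compound 4 the aromatic carbon is ortho to a methoxy group (2 heavy atoms), so this is the same kind of change, not the same. Going by the values given here, the only measured example is the step from compound 2 to compound 1; resting on that single step, and allowing for the different surroundings, compound 4 is expected to fall by a number 0.70 log units lower from compound 3 to compound 4 (beyond the scatter), giving an estimate of 0.5 with a wide range from -1.2 to 2.2.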

Compound 4, distribution coefficient: 2.43
Estimate against measurement, compound 4: 1.93 log units below; the whole stated range lies below it.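

Chloro in place of fluoro on an aromatic carbon gives a number 1.23 log units higher from compound 3 to compound 4 (beyond the scatter) in this assay while the other pair gives a number 2.66 log units lower from compound 2 to compound 1 (beyond the scatter) and so, across these two pairs, the change carries neither its direction nor its size from one core to the other. This does not show which difference between the two cores goes with the reversal, and two pairs set no rule for the series. Nothing at hand bears on the reason for the reversal.

Going by these compounds alone, the methoxy group and the side chain remain unseparated, since no pair here changes either one alone. Going by these compounds, how an amine or a carboxylic acid on that aromatic carbon would compare on either core also stays open.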